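A few compounds are considered here, and "the series" means these few. Any claim that something is new, unique, unknown or untested is made for them only; others in the source may bear on it.

Working notes on the series.

Compound 1, `C[C@@H]1CC(=O)N(c2cnc(NCc3c(F)ccc4c3CCO4)n3cnnc23)C1`, is measured in a physicochemical assay for lipophilicity, using the shake flask method, in phosphate buffer, measured as octanol-water partition, with a stated time of 30 min, at pH 7.4 (on this read-out lower numbers stand for lower lipophilicity and higher numbers for higher lipophilicity), at 1.8. Compound 2, `CNC(=O)c1ccc(-c2cnc(NCc3c(F)ccc4c3CCO4)c3cn[nH]c(=O)c23)c(C)n1`, gives 2.9 in this assay. Among the compounds with values here, of the two numbers known so far, compound 1 is the lower one, and its gap to compound 2 lies beyond the scatter. Within the data shown here, no pair of measured compounds differs in a single place, so no measured step is available to lean on.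

Compound 3, `O=C1CC2(CC2)CN1c1cnc(NCc2c(F)ccc3c2CCO3)n2cnnc12`, remains to be measured in this assay. It differs from compound 1 as follows:

a group of 8 heavy atoms (6 carbon, 1 nitrogen, 1 oxygen; one three-membered non-aromatic ring of carbon only, one five-membered non-aromatic ring with 1 hetero atom) in place of a group of 7 heavy atoms (5 carbon, 1 nitrogen, 1 oxygen; one five-membered non-aromatic ring with 1 hetero atom), on an aromatic carbon

The groups leaving and entering match in donors and acceptors and in the kind of five-membered ring, the entering one adding a three-membered carbon ring. A small rise in this assay is expected for compound 3 relative to compound 1, close to the edge of the scatter, the expected step being a number 0.30 log units higher from compound 1 to compound 3 (within the scatter). Compound 3 is estimated at 2.1, with a range from 1.7 to 2.5.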

Compound 3, distribution coefficient: 1.9
The estimate for compound 3 lay 0.20 log units above the measured number; low and high end bracket the measured number.
By their numbers in this assay, from the lowest: compounds 1 and 3 (each within the scatter of the next); then compound 2.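

In this assay, the first single-place step measured at this aromatic carbon reads a number 0.10 log units higher from compound 1 to compound 3 (within the scatter). Exchanging the 4-methyl-2-oxopyrrolidin-1-yl group for the group carrying a three-membered carbon ring, an exchange that also removes the defined stereocentre, therefore gives no difference that can be told from the scatter at this position. Nothing on hand bears on what lies behind this outcome.

On these data alone, both groups compared here keep the five-membered non-aromatic ring with its carbonyl, so it remains open how the read-out responds at this position to a different kind of group, such as an amine or a carboxylic acid. Compound 2 differs from compound 1 in more than one place and so adds no reading of this position.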